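Sulfamoyl for nitrile on the aryl of compound 3

The source may hold more compounds than are shown below. What is called first, only, known or untested is meant among the compounds shown, and "the series" means these compounds.

The series shares one core, carrying two 4-fluorophenyl groups on a methine and a carboxymethyl group on the five-membered ring, and varies the aryl group attached to that ring. Compound 1 `O=C(O)Cc1sc(C(c2ccc(F)cc2)c2ccc(F)cc2)nc1-c1ccccc1` gives 240 nM in an in vitro functional assay on HEK285-7 cells for antagonist activity at prostaglandin D2 receptor 2 (Homo sapiens), read by BRET and beta-arrestin recruitment; a lower number here means a stronger inhibitor, a higher number a weaker inhibitor. Compound 2 `O=C(O)Cc1sc(C(c2ccc(F)cc2)c2ccc(F)cc2)nc1-c1cc(F)cc(F)c1` gives 340 nM in this assay, a change of a 1.4-fold higher number from compound 1 to compound 2 (0.15 log units; within the scatter). Compound 3 `N#Cc1ccc(-c2nc(C(c3ccc(F)cc3)c3ccc(F)cc3)sc2CC(=O)O)cc1` gives 1500 nM in this assay, the highest of the three numbers, reached by a 6.3-fold higher number from compound 1 to compound 3 (0.80 log units; beyond the scatter) and by a 4.4-fold higher number from compound 2 to compound 3 (0.64 log units; beyond the scatter).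

Compound 4 `NS(=O)(=O)c1cccc(-c2nc(C(c3ccc(F)cc3)c3ccc(F)cc3)sc2CC(=O)O)c1` differs from compound 3 by 3-sulfamoylphenyl in place of 4-cyanophenyl on an aromatic carbon. Going by the values given here, no measured compound carries a sulfamoyl group, so the step has no direct precedent. The two steps that bear on it, from compound 1 and from compound 2 into compound 3, show that the 4-cyanophenyl gives a higher number than either phenyl or 3,5-difluorophenyl; the step from compound 3 to compound 4 removes that nitrile again, so a somewhat lower number is expected, though not with confidence. For compound 4 a step of a 2.5-fold lower number from compound 3 to compound 4 (0.40 log units; beyond the scatter) is estimated in this assay. Compound 4 is expected to give about 600 nM, within a range of 150 nM to 2500 nM.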

Compound 4, half-maximal inhibitory concentration: 710 nM
Beside the measured number, compound 4's estimate is 1.2-fold (0.07 log units) below it; the measured number falls inside the stated range.
By their numbers in this assay, from the lowest: compounds 1 and 2 (each within the scatter of the next); then compound 4; then compound 3.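

In this assay, the position on the five-membered ring accepts 3-sulfamoylphenyl, a larger group than 4-cyanophenyl that adds a hydrogen-bond donor, with a modest gain: a 2.1-fold lower number from compound 3 to compound 4 (0.32 log units; beyond the scatter), so the high number of compound 3 is not shared by every substituted phenyl here. Even so, the sulfamoyl group does not match the plainer aryl groups, with a 3.0-fold higher number from compound 1 to compound 4 (0.47 log units; beyond the scatter) and a 2.1-fold higher number from compound 2 to compound 4 (0.32 log units; beyond the scatter); both the nitrile and the sulfamoyl group now give numbers beyond the scatter of phenyl, while the 3,5-difluorophenyl of compound 2 is the one substituted aryl that stays within it. No measured evidence on these compounds bears on why the sulfamoyl group gives this result.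

The change from 4-cyanophenyl to 3-sulfamoylphenyl alters the group and its place on the phenyl together, and the compounds shown do not separate these two contributions. From the compounds shown here alone, it also remains open whether a methylsulfonyl group, which lacks the sulfamoyl nitrogen, or a simple amine on the same phenyl would bring the number closer to that of compound 1.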